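A few compounds are considered here, and "the series" means these few. Any claim that something is new, unique, unknown or untested is made for them only; others in the source may bear on it.

In a functional assay, with a stated time of 20 min, tested at 50 uM (a lower number here means a weaker effect, a higher number a stronger effect of the compound at the concentration tested), compound 1 `COc1cc(/C=C/C(=O)C2=C(/C=C/c3ccc(O)c(OC)c3)NC(=O)NC2c2ccc(O)cc2)ccc1O` gives 90.3%. Compound 2 `COc1cc(/C=C/C(=O)C2=C(/C=C/c3ccc(O)c(OC)c3)NC(=O)NC2c2ccc(N(C)C)cc2)ccc1O` gives 56%, and a number 34.3 percentage points lower from compound 1 to compound 2 (beyond the scatter). Compound 3 `COc1cc(/C=C/C(=O)C2=C(/C=C/c3ccc(O)c(OC)c3)NC(=S)NC2c2ccccc2)ccc1O` gives 48%, the lowest of the three numbers; its gap to compound 2 lies within the scatter, while compound 1 stands beyond it. Compound 4 `COc1cc(/C=C/C(=O)C2=C(/C=C/c3ccc(O)c(OC)c3)NC(=S)NC2c2ccc(C)cc2)ccc1O` differs from compound 3 by methyl in place of hydrogen on an aromatic carbon. Among the measured compounds shown here, no measured step shows this exchange; the one step in the set, from compound 1 to compound 2, exchanges a different pair of groups and was large, so it does not bear directly on a methyl entering. Compound 4 is thus expected to stay close to compound 3, with no change at the digits printed from compound 3 to compound 4 (within the scatter) lying within the scatter. Compound 4 is therefore estimated at 48%, with a range from 30% to 66%.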

Compound 4, a percentage reported as activity, at one concentration (the size of the read-out at that concentration, not a potency): 62%
Estimate against measurement, compound 4: 14 percentage points below, and the stated range covers the measured number.
By their numbers in this assay, from the lowest: compounds 3, 2 and 4 (each within the scatter of the next, the first and the last beyond it); then compound 1.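

Methyl in place of hydrogen on an aromatic carbon, para to a large group, raises the read-out in this assay (a number 14 percentage points higher from compound 3 to compound 4 (beyond the scatter)). Among the compounds shown here, this is the first step in the set that starts from phenyl and the first in which the number rises, so this position can respond to a single added carbon. Nothing measured here accounts for the rise. From the compounds shown here alone, whether a longer chain such as ethyl, or a methoxy group or a chlorine atom, would give a similar number at this position remains open.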